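This account rests on a few compounds, and the source may have more. Where it says the series, first, only, none or still open, it means among the compounds named here.

Working notes on the series. The shared core is an amide carrying an aryl group on its nitrogen, as in compound 1 `Cc1ccc(NC(=O)C2CCN(C/C=C/c3ccccc3)CC2)cc1`. Among the compounds with values here, in a functional assay on HepG2 cells (Homo sapiens) for inhibition, read by MTT assay, with a stated time of 72 h (a lower number here means a stronger inhibitor, a higher number a weaker inhibitor), compound 1 gives 33900 nM, the highest of the two numbers measured so far; its nearest neighbour is compound 2 `CC(C)c1ccc(NC(=O)C2CCN(C/C=C/c3ccccc3)CC2)cc1`, which in this assay gives 12200 nM. Within the data shown here, the one step known, a 2.8-fold lower number from compound 1 to compound 2 (0.44 log units; beyond the scatter), arises from isopropyl in place of methyl on an aromatic carbon and lies beyond the scatter.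

Compound 3 `O=C(Nc1cccc(Cl)c1)C1CCN(C/C=C/c2ccccc2)CC1` has not been measured in this assay. It differs from compound 1 by 3-chlorophenyl in place of 4-methylphenyl on an amide-type nitrogen. Among the measured compounds shown here, no measured step covers this change; the step from compound 1 to compound 2 only shows that altering the aryl group can shift the number beyond the scatter. Without a closer precedent, the number for compound 3 in this assay is expected near that of compound 1, with a 1.4-fold lower number from compound 1 to compound 3 (0.13 log units; within the scatter) not clearly beyond the scatter. The estimate for compound 3 is 25000 nM, within 8000 nM to 70000 nM.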

Compound 3, half-maximal inhibitory concentration: 20000 nM
Compound 3: middle estimate off by 1.3-fold (0.10 log units), on the high side; the measured number falls inside the stated range.
By their numbers in this assay, from the lowest: compounds 2, 3 and 1 (each within the scatter of the next, the first and the last beyond it).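

In this assay, 3-chlorophenyl in place of 4-methylphenyl on the amide-type nitrogen gives a 1.7-fold lower number from compound 1 to compound 3 (0.23 log units; within the scatter) and so cannot be told apart from no change. Set against the other measured aryl group, the same position gives a 1.6-fold higher number from compound 2 to compound 3 (0.21 log units; within the scatter) with 3-chlorophenyl in place of 4-isopropylphenyl, so compound 3 is resolved from neither neighbour, even though the two neighbours themselves differ beyond the scatter. Nothing measured bears on why the numbers for these aryl groups fall as they do.

Still open, on these data alone, is whether 4-chlorophenyl would read the same as 3-chlorophenyl. Also open, as far as these compounds go, is whether an amine or a carboxylic acid on the aryl group would shift the number beyond the scatter from compound 3.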